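The source may hold more compounds than are shown below. What is called first, only, known or untested is meant among the compounds shown, and "the series" means these compounds.

For the measured compounds named here, in a functional assay on MCF7 cells (Homo sapiens) for antiproliferative activity, read by MTT assay, with a stated time of 72 h (a higher number here means a weaker inhibitor, a lower number a stronger inhibitor), compound 1 `CNc1nc(-c2cc(OC)c(OC)c(OC)c2)c(-c2ccc(OC)cc2)s1` gives 37.6 nM and compound 2 `CCOc1ccc(-c2sc(NC)nc2-c2cc(OC)c(OC)c(OC)c2)cc1` gives 24.5 nM, so compound 1 stands within the scatter of the only other measured compound. Compound 3 `COc1ccc(-c2sc(N(C)C)nc2-c2cc(OC)c(OC)c(OC)c2)cc1` differs from compound 1 by methyl in place of hydrogen on a nitrogen on an aromatic ring, turning methylamino to dimethylamino. Going by the values given here, the only measured step, a 1.5-fold lower number from compound 1 to compound 2 (0.19 log units; within the scatter), places its methyl elsewhere, on a saturated chain carbon bound to an oxygen on an aromatic ring, and so says little about this nitrogen. Among the compounds with values here, with no measured step at the nitrogen, a moderate and uncertain loss of activity is expected in this assay, an estimated step of a 3.2-fold higher number from compound 1 to compound 3 (0.50 log units; beyond the scatter). Compound 3 is expected at 120 nM, within an estimated range of 30 nM to 600 nM.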

Compound 3, half-maximal inhibitory concentration: 8360 nM
Compound 3: the middle estimate sits 70-fold (1.84 log units) below what was measured, and the stated range ends below it.
By their numbers in this assay, from the lowest: compounds 2 and 1 (each within the scatter of the next); then compound 3.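

The nitrogen proves to be a highly sensitive position in this assay: turning methylamino to dimethylamino brings a 220-fold higher number from compound 1 to compound 3 (2.35 log units; beyond the scatter) and so removes most of the activity. The same methyl on a saturated chain carbon bound to an oxygen on an aromatic ring gave only a 1.5-fold lower number from compound 1 to compound 2 (0.19 log units; within the scatter) and so the outcome of adding this group depends strongly on where it is placed. No measurement here explains the loss at the nitrogen.

The compounds shown leave open how a plain amino group or an ethylamino group on this nitrogen would compare with methylamino.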